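The source may hold more compounds than are shown below. What is called first, only, known or untested is meant among the compounds shown, and "the series" means these compounds.

Of the compounds shown here, three have been measured in a functional assay on A375P cells (Homo sapiens) for cytotoxicity, read by MTT assay, with a stated time of 24 h; on this read-out higher numbers stand for weaker inhibition and lower numbers for stronger inhibition. Compound 1 `CNc1ncnc2c(CNc3cc(NC(=O)c4cccc(C(F)(F)F)c4)ccc3C)cccc12` gives 433 nM, the lowest of the three numbers. Compound 2 `CNc1ncnc2c(CNc3cc(NC(=O)c4ccc(Cl)c(C(F)(F)F)c4)ccc3C)cccc12` gives 9700 nM, and compound 3 `CNc1ncnc2c(CNc3cc(NC(=O)c4ccc(-c5cc(C(F)(F)F)ccc5Cl)o4)ccc3C)cccc12` gives 14900 nM. For the measured compounds named here, the one single-point step among them, a 22-fold higher number from compound 1 to compound 2 (1.35 log units; beyond the scatter), shows that even a small addition on the amide-bearing aromatic ring of compound 1 moved the number a long way.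

Compound 4 `CNc1ncnc2c(CNc3cc(NC(=O)c4ccc(Br)s4)ccc3C)cccc12` is still to be measured. It differs from compound 1 in the same region: 5-bromothiophen-2-yl in place of 3-(trifluoromethyl)phenyl on a carbonyl carbon. Going by the values given here, no measured step covers this exact exchange, so the expectation rests on the sensitivity seen in a 22-fold higher number from compound 1 to compound 2 (1.35 log units; beyond the scatter), which is large, and on the fact that compound 3, which also carries a different aromatic group on that carbonyl carbon, shows a much higher number than compound 1. A weakening is therefore expected, though smaller than either of those, since the group here is itself small. Compound 4 is estimated at 3000 nM, within 800 nM to 12000 nM, meaning an expected step of a 6.9-fold higher number from compound 1 to compound 4 (0.84 log units; beyond the scatter).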

Compound 4, half-maximal inhibitory concentration: 10500 nM
The estimate for compound 4 lay 3.5-fold (0.54 log units) below the measured number; low and high end bracket the measured number.
By their numbers in this assay, from the lowest: compound 1; then compounds 2, 4 and 3 (each within the scatter of the next).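

Swapping the 3-(trifluoromethyl)phenyl on the carbonyl carbon for 5-bromothiophen-2-yl, which has fewer heavy atoms, gives a 24-fold higher number from compound 1 to compound 4 (1.38 log units; beyond the scatter) in this assay, so a smaller group on this carbon does not keep the low number. The step of a 1.1-fold higher number from compound 2 to compound 4 (0.03 log units; within the scatter) shows no real difference, even though these two groups differ in ring type and in heavy atoms, and among the four compounds only the 3-(trifluoromethyl)phenyl amide stands apart from the others. No measurement at hand explains these numbers.

As far as these compounds go, it remains open whether the low number depends on the trifluoromethyl group, on the six-membered ring or on both. A plain phenyl, an unsubstituted thiophen-2-yl, or a thiophene bearing trifluoromethyl in place of bromine would help to separate these possibilities.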